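Trimethoxyphenyl triazole thioethers: from anilide to benzyl amide

The source may hold more compounds than are shown below. What is called first, only, known or untested is meant among the compounds shown, and "the series" means these compounds.

In a functional assay on HCT-116 cells (Homo sapiens) for antiproliferative activity, read by MTT assay, with a stated time of 48 h (on this read-out lower numbers stand for stronger inhibition and higher numbers for weaker inhibition), the measured compounds give:
compound 1 `COc1cc(-c2nnc(SCC(=O)c3ccc(Cl)cc3)n2N)cc(OC)c1OC`: 7500 nM
compound 2 `COc1cc(-c2nnc(SCC(=O)c3ccc(C(F)(F)F)cc3)n2N)cc(OC)c1OC`: 16700 nM
compound 3 `COc1cc(-c2nnc(SCC(=O)Nc3ccccc3)n2N)cc(OC)c1OC`: 1730 nM

Compound 3 stands lowest of the three numbers, set apart by a 4.3-fold lower number from compound 1 to compound 3 (0.64 log units; beyond the scatter) and by a 9.7-fold lower number from compound 2 to compound 3 (0.98 log units; beyond the scatter). Compound 4 `COc1ccc(CNC(=O)CSc2nnc(-c3cc(OC)c(OC)c(OC)c3)n2N)cc1OC` differs from compound 3 by 3,4-dimethoxybenzyl in place of phenyl on an amide-type nitrogen. Among the compounds with values here, no measured step touches the group on the amide nitrogen; the only step that alters an aromatic substituent, a 2.2-fold higher number from compound 1 to compound 2 (0.35 log units; beyond the scatter), was modest, and the two larger steps concern the amide itself, which compound 4 keeps. The expected step of a 1.2-fold higher number from compound 3 to compound 4 (0.06 log units; within the scatter) is therefore small, within or just beyond the scatter, in no firm direction. Compound 4 is estimated at 2000 nM, between 600 nM and 6500 nM.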

Compound 4, half-maximal inhibitory concentration: > 100000 nM
Compound 4: a limit, no number; the forecaster's own chance of this, stated with the estimate: 5%; middle value at least 50-fold (1.69 log units) away from the limit.
By their numbers in this assay, from the lowest: compound 3; then compound 1; then compound 2. At a limit, above all of these: compound 4.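

In this assay, within the data shown here, 3,4-dimethoxybenzyl in place of phenyl on an amide-type nitrogen gives an at least 57-fold higher number from compound 3 to compound 4 (1.76 log units; beyond the scatter), so this position, which no earlier step touched, is far from indifferent to the group it carries. Compound 4 has only a limit of the assay, not a number: the limit of > 100000 nM in this assay, at which 1 of the 4 values shown sits. Keeping the amide therefore does not by itself keep the activity of compound 3.

On these data alone, whether the loss goes with the benzyl carbon or with the two methoxy groups stays open. A plain benzyl or a 3,4-dimethoxyphenyl on the amide nitrogen would separate the two.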